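A few compounds are considered here, and "the series" means these few. Any claim that something is new, unique, unknown or untested is made for them only; others in the source may bear on it.

Working notes on the series. Of the compounds shown here, three share one core and have been measured in an assay on isolated protein for inhibition of histone deacetylase 8 (Homo sapiens), read by fluorescence, with a stated time of 30 min; on this read-out higher numbers stand for weaker inhibition and lower numbers for stronger inhibition. Compound 1 `O=C(COc1ccc2c(c1)CN(C(=O)CCc1ccccc1)[C@H](C(=O)Nc1ccccc1)C2)NO` gives 759 nM in this assay. Compound 2 `COc1ccc(NC(=O)[C@@H]2Cc3ccc(OCC(=O)NO)cc3CN2C(=O)[C@H](CC(C)C)NC(=O)OC(C)(C)C)cc1` gives 163 nM. Compound 3 `COc1ccc(NC(=O)[C@@H]2Cc3ccc(OCC(=O)NO)cc3CN2C(=O)CCCc2ccccc2)cc1` gives 114 nM, which is the low end of the three numbers; the gap from compound 3 to compound 2 is within the scatter, the gap to compound 1 is beyond it, so compound 3 is only separated from compound 1 on these data.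

The next compound, compound 4 `CC[C@H](C)[C@H](N)C(=O)N1Cc2cc(OCC(=O)NO)ccc2C[C@H]1C(=O)Nc1ccc(OC)cc1`, differs from compound 3 in one place: 1-amino-2-methylbutyl in place of 3-phenylpropyl on a carbonyl carbon. Within the data shown here, no measured pair in this set reports such a change directly. The nearest comparison is compound 2, which also carries a carbonyl-linked amino-acid-type group at that nitrogen and gives 163 nM, close to compound 3. On that basis a small step is expected, tending toward a higher number, and it may not exceed the scatter. For compound 4 the expected step is a 2.2-fold higher number from compound 3 to compound 4 (0.34 log units; beyond the scatter). Compound 4 is estimated at 250 nM, with a range from 80 nM to 800 nM.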

Compound 4, half-maximal inhibitory concentration: 1040 nM
The estimate for compound 4 lay 4.2-fold (0.62 log units) below the measured number; measured number above the stated range.
By their numbers in this assay, from the lowest: compounds 3 and 2 (each within the scatter of the next); then compounds 1 and 4 (each within the scatter of the next).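

Among these compounds, exchanging 3-phenylpropyl for 1-amino-2-methylbutyl on this carbonyl carbon gives a 9.1-fold higher number from compound 3 to compound 4 (0.96 log units; beyond the scatter) in this assay, the first single-place step, and it shows that the group held here can move the number well beyond the scatter. Among the compounds shown here, the one step combines several changes: the six-membered aromatic ring leaves, the group becomes smaller, and a nitrogen with a hydrogen-bond donor enters, so it does not assign the rise to any one of them. Nothing measured on hand bears on the reason for the step.

Open, from the compounds shown here alone, is whether the step follows the loss of the aromatic ring or the entry of the amine. A 2-methylbutyl group without the amine, or a 1-amino-3-phenylpropyl group keeping the ring, would separate the two.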